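This account rests on a few compounds, and the source may have more. Where it says the series, first, only, none or still open, it means among the compounds named here.

In an ADME assay on 184B5 cells (Homo sapiens) for cytotoxicity, read by sulforhodamine B assay, with a stated time of 48 h (a higher number here means a weaker inhibitor of growth, a lower number a stronger inhibitor of growth), compound 1 `CCN(CC)CN1C(=O)/C(=N\c2nc3ccc(C)cc3s2)c2c(Br)cccc21` gives 34300 nM. Compound 2 `Cc1ccc2nc(/N=C3\C(=O)N(CN(C)C)c4cccc(Br)c43)sc2c1` differs from compound 1 by dimethylamino in place of diethylamino on a saturated chain carbon bound to an amide-type nitrogen in a ring, and that step, a 2.2-fold higher number from compound 1 to compound 2 (0.34 log units; beyond the scatter), moved the number upward. Compound 3 `CCN(CC)CN1C(=O)/C(=N\c2nc3ccc(C)cc3s2)c2c(Cl)cccc21` stands on a different core, the difference from compound 1 being (chloro in place of bromo on an aromatic carbon); in this assay compound 3 gives 87800 nM, and a 2.6-fold higher number from compound 1 to compound 3 (0.41 log units; beyond the scatter). In this assay compound 2 gives 74800 nM, which lies within the scatter of the number for compound 3.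

Compound 4 `Cc1ccc2nc(/N=C3\C(=O)N(CN(C)C)c4cccc(Cl)c43)sc2c1` has not yet been measured in this assay. It is related to compound 3 by dimethylamino in place of diethylamino on a saturated chain carbon bound to an amide-type nitrogen in a ring, the same change that turned compound 1 into compound 2, now made on the core of compound 3. Within the data shown here, the one measured instance of this change is the step of a 2.2-fold higher number from compound 1 to compound 2 (0.34 log units; beyond the scatter), so a step of similar size is expected here, namely a 2.1-fold higher number from compound 3 to compound 4 (0.31 log units; beyond the scatter), resting on that single precedent and on the value of compound 3, 87800 nM. On that basis compound 4 is estimated at 180000 nM in this assay, with a likely range from 80000 nM to 400000 nM.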

Compound 4, concentration for 50% growth inhibition: 5770 nM
Estimate against measurement, compound 4: 31-fold (1.49 log units) above; the measured number lies below the stated range.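

In this assay, dimethylamino in place of diethylamino did not carry over from the core of compound 1 to the core of compound 3, and the direction of the step reversed, with a 15-fold lower number from compound 3 to compound 4 (1.18 log units; beyond the scatter): the same change on two cores in this assay, a 2.2-fold higher number (0.34 log units; beyond the scatter) from compound 1 to compound 2 and a 15-fold lower number (1.18 log units; beyond the scatter) from compound 3 to compound 4, 33-fold (1.52 log units) apart, beyond the scatter of two such steps. Read along the other edge of the same four compounds, chloro in place of bromo behaves just as differently once dimethylamino is present, with a 13-fold lower number from compound 2 to compound 4 (1.11 log units; beyond the scatter): the same change on two cores in this assay, a 2.6-fold higher number (0.41 log units; beyond the scatter) from compound 1 to compound 3 and a 13-fold lower number (1.11 log units; beyond the scatter) from compound 2 to compound 4, 33-fold (1.52 log units) apart, beyond the scatter of two such steps. The two changes therefore do not act independently in these compounds, so a step measured on one core could not be transferred to the other here, but this single set of four compounds does not show why they interact or how general such behaviour is in the series.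

From the compounds shown here alone, it remains open whether the reversal would also appear with fluoro or iodo on the aromatic carbon. The same question stands for a cyclic amine such as pyrrolidinyl or morpholinyl in place of dimethylamino on the chain carbon.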